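This account rests on a few compounds, and the source may have more. Where it says the series, first, only, none or still open, it means among the compounds named here.

Series notes. Compound 1 `CC1=C(C(=O)Nc2ccc(F)cc2)C(c2ccc([N+](=O)[O-])cc2)N=C(SCc2cccc(Cl)c2)N1` and compound 2 `CC1=C(C(=O)Nc2ccc(F)cc2)C(c2ccc([N+](=O)[O-])cc2)N=C(SCc2ccc(Cl)cc2)N1` share one core; compound 3 `CC1=C(C(=O)Nc2ccc([N+](=O)[O-])cc2)C(c2cccc([N+](=O)[O-])c2)N=C(SCc2cccc(Cl)c2)N1` and compound 4 `CC1=C(C(=O)Nc2ccc([N+](=O)[O-])cc2)C(c2cccc([N+](=O)[O-])c2)N=C(SCc2ccc(Cl)cc2)N1` share a second core, and the difference between the two cores is not broken down here. In a functional assay on the whole organism (artery, strain albino) with Rattus norvegicus as the target, with a stated time of 360 min, at a dose of 10 mg/kg by the oral route (a lower number here means less inhibition, a higher number more inhibition at the dose given (going by the name of the read-out)), compound 1 gives 21.1% and compound 2 gives 39.7%. The change 4-chlorophenyl in place of 3-chlorophenyl on a saturated chain carbon bound to a sulfur made a number 18.6 percentage points higher from compound 1 to compound 2 (beyond the scatter). In this assay compound 3 gives 21.6%, within the scatter of compound 1 and beyond the scatter below compound 2. Compound 4 carries the same change on the second core, (4-chlorophenyl in place of 3-chlorophenyl on a saturated chain carbon bound to a sulfur); the change has been seen only once so far, and both place descriptions read alike. For compound 4 a step of a number 16.4 percentage points higher from compound 3 to compound 4 (beyond the scatter) is expected because the same change gave a number 18.6 percentage points higher from compound 1 to compound 2 (beyond the scatter). In this assay compound 4 is estimated at 38%, expected between 22% and 54%.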

Compound 4, a percentage reported as inhibition, in the whole organism at one dose (the size of the read-out at that dose, not a potency): 33%
Compound 4: middle estimate off by 5 percentage points, on the high side; the measured number falls inside the stated range.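

In this assay, 4-chlorophenyl in place of 3-chlorophenyl on a saturated chain carbon bound to a sulfur gave a number 11.4 percentage points higher from compound 3 to compound 4 (beyond the scatter). The step on the second core points the same way as the earlier one, and the two cannot be told apart in size: the same change on two cores in this assay, a number 18.6 percentage points higher (beyond the scatter) from compound 1 to compound 2 and a number 11.4 percentage points higher (beyond the scatter) from compound 3 to compound 4, 7.2 percentage points apart, within the scatter of two such steps This shows that the change carried across the two cores shown, but it rests on two pairs only and does not show that it would carry to any other core, nor why the 4-chlorophenyl compounds read higher.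

Open, going by these compounds, is how a plain benzyl, or a longer chain carrying an amine, would read on the sulfur in place of either chlorobenzyl. Also open, on these data alone, is whether the step holds at another dose or time.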